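The source may report more compounds than this note shows. Statements on the series, on what has been measured and on what is new or still open speak of the compounds shown alone.

Working notes on the series in a functional assay on the whole organism (strain albino) for inhibition, with Rattus norvegicus as the target, read by paw edema, with a stated time of 180 min, at a dose of 100 mg/kg by the oral route; on this read-out higher numbers stand for more inhibition at the one dose given (going by the name of the read-out) and lower numbers for less inhibition.

Of the compounds shown here, three with the shared core have been measured. Compound 1 `Clc1ccccc1NCc1nc2ccc(Br)cc2[nH]1` gives 22.2%. Compound 2 `Brc1ccc(NCc2nc3ccc(Br)cc3[nH]2)cc1` gives 16.6%. Compound 3 `COc1ccc(NCc2nc3ccc(Br)cc3[nH]2)cc1` gives 12.5%. The numbers of all three lie within the scatter of one another: the gap from compound 3 to compound 2 and the gap from compound 3 to compound 1 are both inside the usual spread of repeat measurements, so no ordering among them can be claimed.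

Going by the values given here, the single measured step that changes one place is a number 4.1 percentage points lower from compound 2 to compound 3 (within the scatter), a change on the aromatic carbon of the aniline ring that left the read-out unmoved beyond the scatter.

Compound 4 `Brc1ccc2nc(CNc3ccccc3)[nH]c2c1` has not yet been measured. It differs from compound 3 by hydrogen in place of methoxy on an aromatic carbon. Among the compounds with values here, the only step that bears on it is the one from compound 2 to compound 3, which touched the same position and stayed within the scatter; there is no measured step in which the methoxy is removed altogether. On that basis the expectation for compound 4 in this assay is a step of about a number 3.5 percentage points higher from compound 3 to compound 4 (within the scatter), that is, no change beyond the scatter.

Compound 4 is therefore estimated at 16%, with a range from 5% to 28%.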

Compound 4, a percentage reported as inhibition, in the whole organism at one dose (the size of the read-out at that dose, not a potency): 22.2%
Estimate against measurement, compound 4: 6.2 percentage points below; low and high end bracket the measured number.
By their numbers in this assay, from the lowest: compounds 3, 2, 1 and 4 (each within the scatter of the next).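

Going by these compounds alone, compound 4 gives the first direct reading of hydrogen on this aromatic carbon, para to a large group, in this assay: the removal of methoxy gives a number 9.7 percentage points higher from compound 3 to compound 4 (within the scatter), and hydrogen in place of bromo gives a number 5.6 percentage points higher from compound 2 to compound 4 (within the scatter). Against the chloro compound, the change gives no change at the digits printed from compound 1 to compound 4 (within the scatter), so none of the three substituents shown separates from hydrogen on this read-out, and neither the heavy atoms nor the hydrogen-bond acceptor that leave with methoxy go with a step beyond the scatter. No supporting data on what lies behind these steps are available for the series.

Still open, from the compounds shown here alone, is whether a group of another kind on this aromatic carbon, such as an amine, a carboxylic acid or a longer chain like butoxy, would give a step beyond the scatter from compound 4. Also open, going by these compounds, is how the read-out responds to a change elsewhere, such as hydrogen or an amine in place of the bromo on the shared core, and whether the small steps seen at this single dose would hold at other doses.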